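The source may report more compounds than this note shows. Statements on the series, on what has been measured and on what is new or still open speak of the compounds shown alone.

- Compound 1 `CC[C@@H](Nc1c(C#N)c(-c2ccc(-c3cccc(C)c3F)cc2)nc2cnccc12)C(N)=O`: 47 nm/s
- Compound 2 `CC[C@@H](Nc1c(C#N)c(-c2ccc(-c3cccc(Cl)c3)cc2)nc2cnccc12)C(N)=O`: 37 nm/s

In an ADME assay on Caco-2 cells (Homo sapiens) for permeability, read by LC-MS, in the apical to basolateral direction, with a stated time of 2 h, tested at 2 uM (on this read-out higher numbers stand for higher permeability and lower numbers for lower permeability), compound 2 gives 37 nm/s, which lies within the scatter of compound 1 at 47 nm/s. Compound 3 `CC[C@@H](Nc1c(C#N)c(-c2ccc(-c3ccccc3OC)cc2)nc2cnccc12)C(N)=O` differs from compound 2 by 2-methoxyphenyl in place of 3-chlorophenyl on an aromatic carbon, para to a large group. Among the compounds with values here, the only measured step that bears on this is a 1.3-fold lower number from compound 1 to compound 2 (0.10 log units; within the scatter), also a change of group on an aromatic carbon. Within the data shown here, no measured compound carries the 2-methoxyphenyl group, so no shift beyond the scatter is expected in this assay. The expected size is a 1.1-fold higher number from compound 2 to compound 3 (0.03 log units; within the scatter). Compound 3 is estimated at 40 nm/s, with an expected range of 18 nm/s to 85 nm/s.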

Compound 3, apparent permeability: 160 nm/s
Compound 3: the middle estimate sits 4.0-fold (0.60 log units) below what was measured, and the stated range ends below it.
By their numbers in this assay, from the lowest: compounds 2 and 1 (each within the scatter of the next); then compound 3.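

In this assay this position, para to a large group, proves sensitive to the group it carries: 2-methoxyphenyl gives a 4.3-fold higher number from compound 2 to compound 3 (0.64 log units; beyond the scatter) and a 3.4-fold higher number from compound 1 to compound 3 (0.53 log units; beyond the scatter), while the two earlier groups stayed within the scatter of each other. The entering group holds one hydrogen-bond acceptor and 3-chlorophenyl none, but this is only a count. Nothing available explains the rise. As far as these compounds go, it remains open whether the gain is specific to the methoxy group or would also appear with 2-ethoxyphenyl, 2-hydroxyphenyl or 2-aminophenyl at this place.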